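A few compounds are considered here, and "the series" means these few. Any claim that something is new, unique, unknown or untested is made for them only; others in the source may bear on it.

Of the compounds shown here, two carry numbers so far. Compound 1 `Clc1ccc(-c2csc(N/N=C/c3cccs3)n2)cc1` in a functional assay, read by spectrophotometry, with a stated time of 15 min, tested at 100 ug/mL (on this read-out lower numbers stand for a weaker effect and higher numbers for a stronger effect at the one concentration tested), gives 97%, the highest of the two numbers. Compound 2 `COC(=O)c1cc(-c2csc(N/N=C/c3ccc(Cl)cc3Cl)n2)ccc1OCc1ccccc1` in this assay gives 56.1%, a number lower than that of compound 1 by a gap beyond the usual scatter; the two differ in more than one place, so nothing is drawn from the pair beyond what the values show.

Compound 3 `Cc1ccc(-c2csc(N/N=C/c3cccs3)n2)cc1` is not yet measured in this assay. It differs from compound 1 in one place: methyl in place of chloro on an aromatic carbon. For the measured compounds named here, no measured pair bears on a methyl against a chloro at that position, so the expectation rests on compound 1 alone and on the small size of the change. For compound 3 the expected step is a number 9 percentage points lower from compound 1 to compound 3 (within the scatter), within the scatter or at most a small fall. The number for compound 3 is expected near 88%, within 70% to 98%.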

Compound 3, a percentage reported as inhibition, at one concentration (the size of the read-out at that concentration, not a potency): 98.1%
Compound 3: the middle estimate sits 10.1 percentage points below what was measured; the measured number lies above the stated range.
By their numbers in this assay, from the lowest: compound 2; then compounds 1 and 3 (each within the scatter of the next).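

In this assay, methyl in place of chloro on the aromatic carbon para to a large group gives a number 1.1 percentage points higher from compound 1 to compound 3 (within the scatter), so the two groups cannot be told apart at this position on this read-out. For the compounds shown here, this is the first one-place comparison, and it shows that the chloro group is not needed for the effect seen at the one concentration tested, since methyl serves equally well there. Going by these compounds alone, nothing measured so far explains this match.

From the compounds shown here alone, the read-out gives the size of the effect at one concentration and not a potency, so any difference between compound 1 and compound 3 at other concentrations stays open. Also open, going by these compounds, is whether a group of another kind at this position, such as an amine, a carboxylic acid or a longer chain, would keep the effect.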